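Triazole Sulfides and Liver Cell Toxicity

A few compounds are considered here, and "the series" means these few. Any claim that something is new, unique, unknown or untested is made for them only; others in the source may bear on it.

Three compounds were examined in an ADME assay on HepG2 cells (Homo sapiens) for cytotoxicity, with a stated time of 48 h; a higher number here means a weaker inhibitor, a lower number a stronger inhibitor. Compound 1 `Cn1c(SCc2ccccc2)nnc1-c1cc([N+](=O)[O-])cc([N+](=O)[O-])c1` returns only a limit of the assay, > 30000 nM. Compound 2 `Cn1c(SCc2ccc(Cl)c(Cl)c2)nnc1-c1cc([N+](=O)[O-])cc([N+](=O)[O-])c1` likewise reaches only a limit, > 30000 nM. Compound 3 `O=[N+]([O-])c1cc(-c2nnc(SCc3ccc(Cl)c(Cl)c3)n2Cc2ccccc2)cc(C(F)(F)F)c1` also sits at a limit, > 30000 nM. Every shown value rests at the limit of > 30000 nM in this assay, at which 3 of the 3 values shown sit, so no compound can be ranked against another.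

From compound 2 to compound 1 the change is phenyl in place of 3,4-dichlorophenyl on a saturated chain carbon bound to a sulfur, and the resulting step that the two limits leave unreadable from compound 2 to compound 1 cannot be read, because both ends are limits. How the core of compound 3 differs from that of compound 2 is not broken down here.

Compound 4 `O=[N+]([O-])c1cc(-c2nnc(SCc3ccccc3)n2Cc2ccccc2)cc(C(F)(F)F)c1` has not yet been measured in this assay. It is related to compound 3 by the same change: phenyl in place of 3,4-dichlorophenyl on a saturated chain carbon bound to a sulfur. The step from compound 3 to compound 4 is expected to be a step that the limit leaves unreadable from compound 3 to compound 4, an expectation that rests on the earlier step that the two limits leave unreadable from compound 2 to compound 1, which two limits left unreadable. In this assay compound 4 is therefore estimated at 40000 nM, with a range expected from 15000 nM to 150000 nM.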

Compound 4, half-maximal inhibitory concentration: 21500 nM
The estimate for compound 4 lay 1.9-fold (0.27 log units) above the measured number; the measured number falls inside the stated range.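

In this assay, phenyl in place of 3,4-dichlorophenyl on a saturated chain carbon bound to a sulfur gives, on the core of compound 3, an at least 1.3-fold lower number from compound 3 to compound 4 (0.14 log units; that floor lies within the scatter). Compound 3 stands only at a limit of the assay, > 30000 nM, so this step is a floor and does not establish a real change. The same change on the core of compound 2 cannot be read, so the two cores offer no pair of sizes to compare, and the data neither show that the change carries from one core to the other nor show that it fails to, with most values resting at one limit: the limit of > 30000 nM in this assay, at which 3 of the 4 values shown sit.

The compounds shown leave open whether any group at this place would move the numbers clearly away from that limit. An amine or a carboxylic acid on the phenyl, or a longer chain in place of benzyl, would be among the changes still untested by these compounds.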